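A few compounds are considered here, and "the series" means these few. Any claim that something is new, unique, unknown or untested is made for them only; others in the source may bear on it.

In an ADME assay on NIH3T3 cells (Mus musculus) for cytotoxicity, read by MTT assay, with a stated time of 24 h (a higher number here means a weaker inhibitor, a lower number a stronger inhibitor), compound 1 (`Cc1ccc(/C=N/NC(=O)CSc2nnc(-c3ccncc3)o2)cc1`) reads 185000 nM while compound 2 (`O=C(CSc1nnc(-c2ccncc2)o1)N/N=C/c1cccc(F)c1`) reads 205000 nM and compound 3 (`O=C(CSc1nnc(-c2ccncc2)o1)N/N=C/c1cc(Cl)ccc1O`) reads 166000 nM on the same scale. Compound 3 therefore sits level with the other two, within the scatter of both. Compound 4 (`O=C(CSc1nnc(-c2ccncc2)o1)N/N=C/c1cccs1`) differs from compound 3 at one place, with thiophen-2-yl in place of 5-chloro-2-hydroxyphenyl on a carbon with a double bond to nitrogen. The measured steps at this place are small: a 1.1-fold higher number from compound 1 to compound 2 (0.04 log units; within the scatter) and a 1.1-fold lower number from compound 1 to compound 3 (0.05 log units; within the scatter) and a 1.2-fold lower number from compound 2 to compound 3 (0.09 log units; within the scatter) all stay within the scatter. On these data alone, none of them brings in a five-membered aromatic ring, so thiophen-2-yl remains untested. In this assay no step beyond the scatter is expected in either direction, and an estimated 1.1-fold higher number from compound 3 to compound 4 (0.05 log units; within the scatter) is what that leaves. For compound 4 the expected value is 185000 nM with 110000 nM and 300000 nM as the ends of its estimated range.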

Compound 4, half-maximal inhibitory concentration: 189000 nM
Compound 4: the middle estimate sits 1.0-fold (0.01 log units) below what was measured, and the stated range covers the measured number.
By their numbers in this assay, from the lowest: compounds 3, 1, 4 and 2 (each within the scatter of the next).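

In this assay, thiophen-2-yl, the first five-membered aromatic ring at this position, leaves the reading level with all three compounds carrying a six-membered ring there (a 1.1-fold higher number from compound 3 to compound 4 (0.06 log units; within the scatter)) and (a 1.1-fold lower number from compound 2 to compound 4 (0.04 log units; within the scatter)) and (a 1.0-fold higher number from compound 1 to compound 4 (0.01 log units; within the scatter)). Replacing a six-membered aromatic ring of carbon only with a five-membered one holding a hetero atom, and giving up the hydrogen-bond donor of compound 3, therefore produces no step beyond the scatter. No evidence is available to explain this result. On these data alone, whether the reading stays level with an amine, a carboxylic acid or a longer alkyl chain on this carbon remains open.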